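From Acetamido to Methyl(methylsulfonyl)amino on a Shared Core

The source may report more compounds than this note shows. Statements on the series, on what has been measured and on what is new or still open speak of the compounds shown alone.

Of the compounds shown here, three have so far been tested in a functional assay on Urethra for agonist activity at Alpha-1A adrenergic receptor (Oryctolagus cuniculus); a lower number here means a less potent compound, a higher number a more potent compound, by a factor of ten per unit of this negative logarithm. Compound 2 `CC(=O)Nc1cccc2c1CCCC2c1c[nH]cn1` gives 5.89, the second highest of the three numbers. Compound 3 `CS(=O)(=O)Nc1cccc2c1OCCC2c1c[nH]cn1` gives 6, which lies within the scatter of compound 2, while compound 1 `CS(=O)(=O)Nc1ccc(Cl)c2c1CCCC2c1c[nH]cn1` gives 4.35, a number far below compound 2 and beyond the scatter. Compound 4 `CN(c1cccc2c1CCCC2c1c[nH]cn1)S(C)(=O)=O` has not yet been measured. It differs from compound 2 in a single place: methyl(methylsulfonyl)amino in place of acetamido on an aromatic carbon. For the measured compounds named here, no measured pair isolates this change, so the expectation rests on compound 2 alone. Compound 4 is expected to come out below compound 2, by an estimated step of a number 0.69 log units lower from compound 2 to compound 4 (beyond the scatter), which would reach beyond the scatter. The estimate for compound 4 is 5.2, with a range from 4.4 to 6.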

Compound 4, negative logarithm of the half-maximal effective concentration: 6.16
The estimate for compound 4 lay 0.96 log units below the measured number; measured number outside the range, above it.
By their numbers in this assay, from the lowest: compound 1; then compounds 2, 3 and 4 (each within the scatter of the next).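

In this assay, methyl(methylsulfonyl)amino in place of acetamido on this aromatic carbon gives a number 0.27 log units higher from compound 2 to compound 4 (within the scatter), so the two groups cannot be told apart at this position. The entering group has no hydrogen-bond donor and more heavy atoms, yet in this pair neither difference separates the two numbers. Nothing measured here explains this outcome. Still open, from the compounds shown here alone, is how an amine or a carboxylic acid would read on this same carbon of the shared core.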